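The source may report more compounds than this note shows. Statements on the series, on what has been measured and on what is new or still open speak of the compounds shown alone.

The measurements come from a functional assay on the whole organism (blood) with Rattus norvegicus as the target, with stated times of 24 h and 1 h, at a dose of 5 mg/kg by the intraperitoneal route; a lower number here means a weaker effect, a higher number a stronger effect of the compound at the dose given. The compounds measured so far are:

Compound 1, `COc1ccc(Cl)cc1C(=O)NCC1CCN(S(=O)(=O)NC(=O)NC2CCCCC2)CC1`, which gives 20%
Compound 2, `CCCCCCNC(=O)NS(=O)(=O)N1CCC(CNC(=O)c2cc(Cl)ccc2OC)CC1`, which gives 17%
Compound 3, `COc1ccc(Cl)cc1C(=O)NCCC1CCN(S(=O)(=O)NC(=O)NC[C@@H]2C[C@@H]3C=C[C@@H]2C3)CC1`, which gives 37%

Compound 3 stands highest of these three numbers. Its nearest neighbour is compound 1, whose number lies below it by more than the usual scatter, and compound 2 lies further below still, again beyond the scatter. Among the measured compounds shown here, the only step between two measured compounds that differ in a single place runs a number 3 percentage points lower from compound 1 to compound 2 (within the scatter); that change, hexyl in place of cyclohexyl on an amide-type nitrogen, touches the same end of the molecule as the change now in question but is otherwise of a different kind.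

Compound 4, `COc1ccc(Cl)cc1C(=O)NCCC1CCN(S(=O)(=O)NC(=O)NC[C@H]2C[C@@H]3CC[C@@H]2O3)CC1`, is not yet measured. It differs from compound 3 in one place: a group of 7 heavy atoms (6 carbon, 1 oxygen; 2 five-membered non-aromatic rings with 1 hetero atom each) in place of a group of 7 heavy atoms (7 carbon; 2 five-membered non-aromatic rings of carbon only), on a saturated chain carbon bound to an amide-type nitrogen

For the measured compounds named here, no measured step shows what such an exchange of one bicyclic group for another does here. Going by the values given here, the one step that is known, from hexyl to cyclohexyl, was within the scatter, and a like outcome is the most that can be argued from the data. The change is therefore expected to be a number 5 percentage points lower from compound 3 to compound 4 (within the scatter), with no clear direction. Compound 4 is estimated to give 32% in this assay, in a range from 18% to 46%.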

Compound 4, a percentage reported as activity, at one dose (the size of the read-out at that dose, not a potency): 27%
The estimate for compound 4 lay 5 percentage points above the measured number; measured number inside the range.
By their numbers in this assay, from the lowest: compounds 2, 1, 4 and 3 (each within the scatter of the next, the first and the last beyond it).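

In this assay, the exchange of the all-carbon bicyclic group for the oxygen-bearing one, on a saturated chain carbon bound to an amide-type nitrogen, gives a number 10 percentage points lower from compound 3 to compound 4 (within the scatter). This is the first step shown for a bicyclic group at this place, and it shows that this position tolerates an exchange that brings in one hydrogen-bond acceptor and removes the double bond outside aromatic rings, without separating the two compounds beyond the scatter at the single dose used. Nothing available explains the step or ties it to any property of either group.

The compounds shown leave open whether the ring oxygen or the lost double bond has any bearing on the read-out, a question that a saturated all-carbon bicyclic group at the same place would address. They also leave open how this position would respond to a group of a different kind, such as an amine or a carboxylic acid on the bicyclic group, and whether the read-out would differ at other doses.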